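Ring-nitrogen substituent: acetyl to phenyl in the coumarin-pyrazoline series

The source may report more compounds than this note shows. Statements on the series, on what has been measured and on what is new or still open speak of the compounds shown alone.

Among the measured compounds shown here, compound 3 `COc1ccc2ccc(=O)oc2c1C1=NN(C(C)=O)C(c2ccc(C(F)(F)F)cc2)C1` gives 80 nM in a functional assay on HepG2 cells (Homo sapiens) for cytotoxicity, read by MTT assay, with a stated time of 72 h (a lower number here means a stronger inhibitor, a higher number a weaker inhibitor), and stands second highest of the three numbers measured so far. For the measured compounds named here, its nearest neighbour is compound 1 `COc1ccc2ccc(=O)oc2c1C1=NN(C(N)=O)C(c2ccc(C(F)(F)F)cc2)C1`, which in this assay gives 96 nM; the one step measured in one place, a 1.2-fold lower number from compound 1 to compound 3 (0.08 log units; within the scatter), is within the scatter. Furthest from compound 3 is compound 2 `COc1ccc2ccc(=O)oc2c1C1=NN(c2ccccc2)C(c2ccc(C)cc2)C1`, which in this assay gives 51 nM, also within the scatter of compound 3.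

Compound 4 `COc1ccc2ccc(=O)oc2c1C1=NN(c2ccccc2)C(c2ccc(C(F)(F)F)cc2)C1` is not yet measured. It differs from compound 3 by phenyl in place of acetyl on an amine nitrogen in a ring. Going by the values given here, no measured step covers this exchange directly; the only single-place step in the set, from compound 1 to compound 3, concerns the carbonyl substituent and is within the scatter, and compound 2 carries the phenyl on the ring nitrogen but also a different aryl group, so its value alone cannot separate the two changes. The values of compound 2 and compound 3 suggest that the ring-nitrogen substituents tried so far move this assay little.

For compound 4 a step of a 1.3-fold lower number from compound 3 to compound 4 (0.12 log units; within the scatter) is therefore expected, not beyond the scatter. The estimate for compound 4 in this assay is 60 nM, with a range from 25 nM to 150 nM.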

Compound 4, half-maximal inhibitory concentration: 38 nM
Compound 4: middle estimate off by 1.6-fold (0.20 log units), on the high side; the measured number falls inside the stated range.
By their numbers in this assay, from the lowest: compounds 4, 2, 3 and 1 (each within the scatter of the next, the first and the last beyond it).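

Phenyl on the ring nitrogen now has a direct reading: the exchange for acetyl gives a 2.1-fold lower number from compound 3 to compound 4 (0.32 log units; beyond the scatter) in this assay, and the exchange for carbamoyl gives a 2.5-fold lower number from compound 1 to compound 4 (0.40 log units; beyond the scatter), both modest but beyond the scatter. The aryl change that compound 2 left mixed with the ring-nitrogen change can now be read alone, since a 1.3-fold lower number from compound 2 to compound 4 (0.13 log units; within the scatter), with trifluoromethyl in place of methyl, stays within the scatter. So among these compounds, the steps beyond the scatter sit at the amine nitrogen in the ring, while no data here account for them.

As far as these compounds go, whether the lower number depends on an aromatic ring on this nitrogen remains open, as a benzyl or cyclohexyl group would test. So does the effect of substituents on that phenyl, such as a methoxy group or a carboxylic acid.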